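Acrylamide anilinotriazine series: antiproliferative read-out on Ramos cells

A few compounds are considered here, and "the series" means these few. Any claim that something is new, unique, unknown or untested is made for them only; others in the source may bear on it.

Measured so far in a functional assay on Ramos cells (Homo sapiens) for antiproliferative activity, read by CCK-8 assay, with a stated time of 24 h; on this read-out higher numbers stand for weaker inhibition and lower numbers for stronger inhibition:
compound 1 `C=CC(=O)Nc1cc(Nc2ncnc(Nc3ccc(C(=O)N4CCCCC4)cc3)n2)ccc1C`, 48500 nM
compound 2 `C=CC(=O)Nc1cccc(Nc2ncnc(Nc3ccc(-c4cccnc4)cc3)n2)c1`, > 100000 nM
compound 3 `C=CC(=O)Nc1cccc(Nc2nc(Cl)nc(Nc3ccc(Oc4ccccc4)cc3)n2)c1`, 12300 nM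

Compound 2 gives only a limit, not a number: it sits at the limit of > 100000 nM in this assay, at which 1 of the 3 values shown sits. Compound 1 and compound 3 give numbers, both in the weak range. Compound 4 `C=CC(=O)Nc1cccc(Nc2ncnc(Nc3ccc(C(=O)Nc4ccc(C)cn4)cc3)n2)c1` differs from compound 2 by (5-methylpyridin-2-yl)carbamoyl in place of pyridin-3-yl on an aromatic carbon, para to a large group. Among the measured compounds shown here, no measured pair isolates this change. Compound 1, which also carries a carbamoyl group on that ring, gives 48500 nM, so a step toward stronger inhibition beyond the scatter is expected, as an at least 2.5-fold lower number from compound 2 to compound 4 (0.39 log units; beyond the scatter). For compound 4 the estimate in this assay is 40000 nM, between 12000 nM and 100000 nM.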

Compound 4, half-maximal inhibitory concentration: > 100000 nM
Compound 4 was reported as a limit (the forecaster's own chance of this, stated with the estimate: 30%); middle value at least 2.5-fold (0.39 log units) from the limit.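

No step can be read from compound 2 to compound 4, because both values are limits, not numbers: the limit of > 100000 nM in this assay, at which 2 of the 4 values shown sit.

The compounds shown leave open whether pyridin-3-yl or (5-methylpyridin-2-yl)carbamoyl on that ring gives stronger inhibition.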